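Swapping a benzylamino for two hydroxypropyl chains

This account rests on a few compounds, and the source may have more. Where it says the series, first, only, none or still open, it means among the compounds named here.

Compound 1 `O=C(Nc1ccc(NCc2ccccc2)cc1Cl)c1cc(Cl)ccc1O`: 19700 nM
Compound 2 `O=C(Nc1ccc(NCc2cc(Cl)cc(Cl)c2)cc1Cl)c1cc(Cl)ccc1O`: 13300 nM

In an ADME assay on A549 cells (Homo sapiens) for cytotoxicity, read by resazurin assay, with a stated time of 48 h (a lower number here means that less compound is tolerated, a higher number that more compound is tolerated), compound 1 gives 19700 nM, the highest of the two numbers measured, while compound 2 gives 13300 nM. Among the measured compounds shown here, the one step measured, a 1.5-fold lower number from compound 1 to compound 2 (0.17 log units; within the scatter), keeps the benzylamino in place and only adds chloro groups to its ring, so the two compounds cannot be told apart on these numbers.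

Compound 3 `O=C(Nc1ccc(N(CCCO)CCCO)cc1Cl)c1cc(Cl)ccc1O` is not yet measured in this assay. The change from compound 1 is bis(3-hydroxypropyl)amino in place of benzylamino on an aromatic carbon. The ring of the benzylamino is given up altogether and two open chains, each ending in a hydroxyl, take its place. For the measured compounds named here, the step from compound 1 to compound 2 touches only the substituents on that ring and so gives little guidance here; no measured step follows the loss of the ring itself.

With only this to go on, compound 3 is expected to sit near compound 1, with the step of a 1.3-fold higher number from compound 1 to compound 3 (0.10 log units; within the scatter) expected to stay within the scatter. The estimate for compound 3 is 25000 nM, with a range from 8000 nM to 70000 nM.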

Compound 3, half-maximal cytotoxic concentration: 114000 nM
For compound 3 the middle estimate is 4.6-fold (0.66 log units) below the measured one, and the stated range ends below it.
By their numbers in this assay, from the lowest: compounds 2 and 1 (each within the scatter of the next); then compound 3.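

In this assay, replacing the whole benzylamino with bis(3-hydroxypropyl)amino gives a 5.8-fold higher number from compound 1 to compound 3 (0.76 log units; beyond the scatter), whereas changing only the substituents on the benzylamino ring gives a 1.5-fold lower number from compound 1 to compound 2 (0.17 log units; within the scatter). This aromatic carbon is therefore not indifferent to what it carries: among these compounds, only the exchange of the entire group moves the number beyond the scatter, and the cells tolerate more of compound 3 than of compound 1. The exchange alters several features at once, since the ring leaves, two open chains enter and the counts of hydrogen-bond donors and acceptors rise, and no measurement here gives a reason for the shift.

The compounds shown do not separate the loss of the ring from the arrival of the hydroxyl groups, a question that dipropylamino, with open chains but no hydroxyl, or a single 3-hydroxypropylamino chain could help to settle. As far as these compounds go, it also remains open whether the hydroxyl itself matters or whether another chain end, such as an amine or a carboxylic acid, would give a similar number.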